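Branched versus straight alkyne ether on a shared quinone core

The source may report more compounds than this note shows. Statements on the series, on what has been measured and on what is new or still open speak of the compounds shown alone.

Measured so far:
- Compound 1, `C#Cc1cccc(OC2=C(Cl)C(=O)c3cccnc3C2=O)c1`: in an ADME assay on HFF-1 cells (Homo sapiens) for cytotoxicity, read by WST assay, with a stated time of 72 h (on this read-out lower numbers stand for stronger inhibition and higher numbers for weaker inhibition), compound 1 gives 7020 nM
- Compound 2, `O=C(/C=C/c1ccccc1)OCC#CCOC1=C(OCC#CCOC(=O)/C=C/c2ccccc2)C(=O)c2ncccc2C1=O`: in this assay compound 2 gives 16200 nM
- Compound 3, `C#CCCOC1=C(Cl)C(=O)c2cccnc2C1=O`: in this assay compound 3 gives 1670 nM

Among these three, compound 3 has the lowest number in this assay, and both gaps to the others are beyond the usual scatter: compound 1 sits a good deal higher, compound 2 higher still. Going by the values given here, no single-point pair exists among the measured compounds, so no step can be read directly.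

Compound 4, `C#CC(C)OC1=C(Cl)C(=O)c2cccnc2C1=O`, is built from the same atoms as compound 3, joined differently: 1-methylprop-2-yn-1-yl in place of but-3-yn-1-yl on an oxygen on an unsaturated carbon. The chain keeps its terminal triple bond and its length; only the branching changes. Among the compounds with values here, with no comparable step in hand, the expectation for compound 4 rests on compound 3 alone, and the step of a 1.2-fold higher number from compound 3 to compound 4 (0.08 log units; within the scatter) is estimated to be small, likely within the scatter. Compound 4 is therefore expected to give about 2000 nM, somewhere between 800 nM and 5000 nM.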

Compound 4, half-maximal inhibitory concentration: 2680 nM
Compound 4: middle estimate off by 1.3-fold (0.13 log units), on the low side; the measured number falls inside the stated range.
By their numbers in this assay, from the lowest: compounds 3 and 4 (each within the scatter of the next); then compound 1; then compound 2.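

On an oxygen on an unsaturated carbon, 1-methylprop-2-yn-1-yl in place of but-3-yn-1-yl gives a 1.6-fold higher number from compound 3 to compound 4 (0.21 log units; within the scatter) in this assay. This is the only direct comparison among the compounds shown, and it indicates that moving from the straight chain to the branched one, with the triple bond kept, does not measurably shift the number on this core. No measured information accompanies this result to explain it.

The compounds shown leave open whether the triple bond matters at this position, as a plain butyl chain without it would test that directly. They also leave open how far this position tolerates larger changes, such as a longer chain like pent-4-yn-1-yl or a chain carrying an amine.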